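Lengthening the Propyl Chain to Butyl

The source may report more compounds than this note shows. Statements on the series, on what has been measured and on what is new or still open speak of the compounds shown alone.

Going by the values given here, in a functional assay on cells (T-cell line, Homo sapiens) for inhibition (on this read-out lower numbers stand for stronger inhibition and higher numbers for weaker inhibition), compound 2 (`CCCN1CCC(COC(c2ccccc2)c2ccccc2)CC1`) stands at 17800 nM, the higher of the two numbers so far, while compound 1 (`Cc1ccc(CCCN2CCC(COC(c3ccccc3)c3ccccc3)CC2)cc1`) gives 200 nM. Compound 3 (`CCCCN1CCC(COC(c2ccccc2)c2ccccc2)CC1`) differs from compound 2 by methyl in place of hydrogen on a saturated chain carbon, three bonds along the chain from an amine nitrogen in a ring, which turns propyl into butyl. Among the compounds with values here, one measured step bears on this change at the same carbon: an 89-fold higher number from compound 1 to compound 2 (1.95 log units; beyond the scatter), a large step in which hydrogen replaces 4-methylphenyl. Read backwards, that step links a group at this carbon with a lower number. Methyl is only a fragment of 4-methylphenyl, however, so just a small part of that size is expected, in the same direction and close to the scatter. The expected change is a 2.0-fold lower number from compound 2 to compound 3 (0.30 log units; within the scatter). For compound 3 the estimate is 9000 nM, with an expected range from 3500 nM to 20000 nM.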

Compound 3, half-maximal inhibitory concentration: 14000 nM
Compound 3: the middle estimate sits 1.6-fold (0.19 log units) below what was measured, and the stated range covers the measured number.
By their numbers in this assay, from the lowest: compound 1; then compounds 3 and 2 (each within the scatter of the next).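

In this assay, methyl in place of hydrogen on this saturated chain carbon gives a 1.3-fold lower number from compound 2 to compound 3 (0.10 log units; within the scatter) and so leaves propyl and butyl indistinguishable on this read-out. Methyl in place of 4-methylphenyl at the same carbon gives a 70-fold higher number from compound 1 to compound 3 (1.85 log units; beyond the scatter) and is a large step like the one seen with hydrogen, so among these three compounds the low number goes with 4-methylphenyl and not with the single added carbon. No evidence on hand accounts for this result.

The compounds shown leave open whether an unsubstituted phenyl, without the methyl of 4-methylphenyl, would keep the lower number. They also leave open how a longer chain such as pentyl or hexyl, or a hydroxyl on the butyl chain, would read here.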